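Benzamide series: difluorobenzyl swap on the dimethylamino analogue

The source may report more compounds than this note shows. Statements on the series, on what has been measured and on what is new or still open speak of the compounds shown alone.

Measured compounds:
compound 1 `CC1(C)c2[nH]nc(NC(=O)c3ccccc3)c2CN1Cc1cc(F)cc(F)c1`, 190 nM
compound 2 `CC1(C)c2[nH]nc(NC(=O)c3ccccc3)c2CN1Cc1cccc(F)c1F`, 200 nM
compound 3 `CN(C)c1ccc(C(=O)Nc2n[nH]c3c2CN(Cc2cccc(F)c2F)C3(C)C)cc1`, 69 nM

All three were read in an assay on Sf21 cells for inhibition of high affinity nerve growth factor receptor (Homo sapiens), read by HTRF, with a stated time of 30 min, in the presence of a further agent that is not named here; a lower number here means a stronger inhibitor, a higher number a weaker inhibitor. Compound 2 and compound 1 differ only by 3,5-difluorophenyl in place of 2,3-difluorophenyl on a saturated chain carbon bound to an amine nitrogen in a ring; this gave a 1.1-fold lower number from compound 2 to compound 1 (0.02 log units; within the scatter). Compound 3 carries a different core from compound 2, the difference being (dimethylamino in place of hydrogen on an aromatic carbon), and this step gave a 2.9-fold lower number from compound 2 to compound 3 (0.46 log units; beyond the scatter). Compound 3 has the lowest number of the three, and its steps to both compound 1 and compound 2 are beyond the scatter.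

Compound 4 `CN(C)c1ccc(C(=O)Nc2n[nH]c3c2CN(Cc2cc(F)cc(F)c2)C3(C)C)cc1` is not yet measured. It differs from compound 3 by 3,5-difluorophenyl in place of 2,3-difluorophenyl on a saturated chain carbon bound to an amine nitrogen in a ring, which is the same change as that between compound 2 and compound 1, made at the same place, but on the core of compound 3 rather than the core of compound 2. Since that earlier step was a 1.1-fold lower number from compound 2 to compound 1 (0.02 log units; within the scatter), the step expected from compound 3 to compound 4 in this assay is about a 1.1-fold lower number from compound 3 to compound 4 (0.03 log units; within the scatter), resting on a single prior instance of the change. Compound 4 is therefore estimated at 65 nM, with a range from 30 nM to 140 nM.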

Compound 4, half-maximal inhibitory concentration: 96 nM
Beside the measured number, compound 4's estimate is 1.5-fold (0.17 log units) below it; low and high end bracket the measured number.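

In this assay, moving from 2,3-difluorobenzyl to 3,5-difluorobenzyl on the dimethylamino core gives a 1.4-fold higher number from compound 3 to compound 4 (0.14 log units; within the scatter), and this step agrees with the same change on the core of compound 2: the same change on two cores in this assay, a 1.1-fold lower number (0.02 log units; within the scatter) from compound 2 to compound 1 and a 1.4-fold higher number (0.14 log units; within the scatter) from compound 3 to compound 4, 1.5-fold (0.17 log units) apart, within the scatter of two such steps.

Adding dimethylamino to the 3,5-difluorobenzyl compound gives a 2.0-fold lower number from compound 1 to compound 4 (0.30 log units; within the scatter), and this step also agrees with its counterpart in the 2,3-difluorobenzyl pair, even though only that counterpart lies beyond the scatter: the same change on two cores in this assay, a 2.9-fold lower number (0.46 log units; beyond the scatter) from compound 2 to compound 3 and a 2.0-fold lower number (0.30 log units; within the scatter) from compound 1 to compound 4, 1.5-fold (0.17 log units) apart, within the scatter of two such steps.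

Both changes therefore carry across this single square of compounds without a detectable interaction, but each comparison rests on one pair per core, and the difluorobenzyl change is too small on either core to show that a larger step would carry over, or that the agreement extends to other cores.

From the compounds shown here alone, it remains open whether a cyclic amine such as morpholine or piperazine could stand in place of dimethylamino with a similar step. Also open, going by these compounds, is how an unsubstituted benzyl or a longer chain would compare with the difluorobenzyl groups.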